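Exchanging the group on the double-bonded nitrogen

The source may report more compounds than this note shows. Statements on the series, on what has been measured and on what is new or still open speak of the compounds shown alone.

Compound 1, `COc1cc(/C(=N/OC(C)=O)c2ccc3c(ccn3C)c2)cc(OC)c1OC`: > 10000 nM
Compound 2, `COc1cc(/C(=N/NC(C)=O)c2ccc3c(ccn3C)c2)cc(OC)c1OC`: > 1000 nM

In a functional assay on HL-60 cells (Homo sapiens) for cytotoxicity, read by XTT assay, with a stated time of 72 h (a lower number here means a stronger inhibitor, a higher number a weaker inhibitor), compound 1 gives > 10000 nM, which is a limit of the assay and not a number. In this assay compound 2 gives > 1000 nM, again a limit rather than a measured number. Among the compounds with values here, the one step between the two, a step that the two limits leave unreadable from compound 1 to compound 2, cannot be read because the limit of > 1000 nM in this assay, at which 1 of the 2 values shown sits, and the limit of > 10000 nM in this assay, at which 1 of the 2 values shown sits, are both limits. Compound 2 therefore stands at a limit, with no numerical value to place it against; both values shown so far are limits.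

Compound 3, `COc1cc(/C(=N/C(=O)OC(C)(C)C)c2ccc3c(ccn3C)c2)cc(OC)c1OC`, differs from compound 2 by tert-butoxycarbonyl in place of acetamido on a double-bonded nitrogen. Within the data shown here, no measured step bears directly on this change: the only step available is unreadable, and it says merely that neither neighbour of compound 2 reached a number in this assay. Both known compounds sit at limits, so the step that the limit leaves unreadable from compound 2 to compound 3 is expected to leave compound 3 in the same weak region, with no readable direction. For compound 3 the estimated value in this assay is 5000 nM, with a range from 1000 nM to 30000 nM, and most likely only a limit would be reported.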

Compound 3, half-maximal inhibitory concentration: > 1000 nM
Compound 3 ended at the assay's limit; the forecaster's own chance of this, stated with the estimate: 70%; the middle value lies beyond the limit too.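

In this assay compound 3 gives > 1000 nM, a limit of the assay and not a number. Its steps from compound 1 and from compound 2 cannot be read. The three compounds leave open how strongly each one acts in this assay, and whether exchanging the group on the double-bonded nitrogen changes that at all.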